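The compounds below may be only part of what the source reports. "The series", "measured", "known", "first", "only" and "open" are said of these compounds alone.

Series notes. In an assay on isolated protein for inhibition of Leucine-rich repeat serine/threonine-protein kinase 2 variant G2019S (Homo sapiens), read by TR-FRET and LanthaScreen, with stated times of 50 min and 30 min, in the presence of a further agent that is not named here (a higher number here means a weaker inhibitor, a lower number a stronger inhibitor), compound 1 `Cn1c(N2CCCC2)c(C#N)c2c(N)ncnc21` gives 1910 nM; compound 2 `CN(C)c1c(C#N)c2c(N)ncnc2n1C` gives 3760 nM; compound 3 `C[C@@H]1CCCN1c1c(C#N)c2c(N)ncnc2n1C` gives 11 nM, the lowest of the three numbers, with both its steps, a 170-fold lower number from compound 1 to compound 3 (2.24 log units; beyond the scatter) and a 340-fold lower number from compound 2 to compound 3 (2.53 log units; beyond the scatter), beyond the scatter. The remaining measured step, a 2.0-fold higher number from compound 1 to compound 2 (0.29 log units; within the scatter), is within the scatter. Compound 4 `C[C@@H]1CCCN1c1cc2c(N)ncnc2n1C` is not yet measured and differs from compound 3 as follows: hydrogen in place of cyano on an aromatic carbon. Every measured step leaves the cyano untouched, so none of them bears on this change, and its direction in this assay cannot be read from the series. Among the measured compounds shown here, with no precedent, the expected step is a 5.5-fold higher number from compound 3 to compound 4 (0.74 log units; beyond the scatter), a modest loss inside a wide range. Compound 4 is therefore estimated at 60 nM, between 10 nM and 400 nM.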

Compound 4, half-maximal inhibitory concentration: 6390 nM
Beside the measured number, compound 4's estimate is 110-fold (2.03 log units) below it; the whole stated range lies below it.
By their numbers in this assay, from the lowest: compound 3; then compounds 1, 2 and 4 (each within the scatter of the next, the first and the last beyond it).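

In this assay, among the compounds shown here, hydrogen in place of cyano on this aromatic carbon gives a 580-fold higher number from compound 3 to compound 4 (2.76 log units; beyond the scatter) and so shows that this position, unchanged across the earlier compounds, strongly affects the number. The 2-methylpyrrolidin-1-yl group alone does not secure a low number: among these compounds, only compound 3 carries it together with the cyano. Nothing available explains the size of this step.

From the compounds shown here alone, whether a carboxamide, a chlorine or an ethynyl group could stand in for the cyano remains open. So does whether any group other than cyano at this carbon would keep the number of compound 3.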